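This account rests on a few compounds, and the source may have more. Where it says the series, first, only, none or still open, it means among the compounds named here.

Measured compounds:
compound 1 `O=C1C=C(Nc2cccc(Cl)c2)C(=O)c2c1nc1n2[C@H]2OC[C@@H](O)[C@H]2OC1`: 4720 nM
compound 2 `O=C1C(Nc2ccc(I)cc2)=CC(=O)c2c1nc1n2[C@H]2OC[C@@H](O)[C@H]2OC1`: 3890 nM

In a functional assay on MCF7 cells (Homo sapiens) for inhibition, read by sulforhodamine B assay (on this read-out higher numbers stand for weaker inhibition and lower numbers for stronger inhibition), compound 1 gives 4720 nM, and in this assay compound 2 gives 3890 nM. The two numbers sit within the usual scatter of each other, so nothing separates compound 1 from compound 2 on what has been measured. Both carry an aryl amine on the shared core, and no other variation at that position has yet been tested.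

Compound 3 `O=C1C=C(N2CCCC2)C(=O)c2c1nc1n2[C@H]2OC[C@@H](O)[C@H]2OC1` takes that position in a different direction. Its change from compound 1 is pyrrolidin-1-yl in place of (3-chlorophenyl)amino on a double-bonded ring carbon: the aryl amine and its single hydrogen-bond donor give way to a saturated five-membered ring. Going by the values given here, no measured pair shows the effect of such an exchange, so the direction of the step can only be guessed. With the two aryl amines indistinguishable, a modest move toward weaker inhibition, or none beyond the scatter, seems the most likely outcome, and the expected step of a 1.5-fold higher number from compound 1 to compound 3 (0.17 log units; within the scatter) is set accordingly. Compound 3 is therefore estimated at 7000 nM in this assay, within a range from 2500 nM to 20000 nM.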

Compound 3, half-maximal inhibitory concentration: > 16000 nM
Compound 3 ended at the assay's limit; the forecaster's own chance of this, stated with the estimate: 10%; middle value at least 2.2-fold (0.35 log units) away from the limit.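

In this assay compound 3 gives > 16000 nM, which is a limit of the assay and not a number. Going by these compounds alone, replacing (3-chlorophenyl)amino with pyrrolidin-1-yl on the double-bonded ring carbon gives an at least 3.3-fold higher number from compound 1 to compound 3 (0.53 log units; beyond the scatter), the first step beyond the scatter at this position, which compound 1 and compound 2 alone could not show: the group held there can matter for inhibition of these cells, and the aryl amine gives the stronger inhibition of this pair. The step has a lower bound but no upper one, and its full size stays unknown: the limit of > 16000 nM in this assay, at which 1 of the 3 values shown sits.

The exchange removes the aromatic ring and the hydrogen-bond donor together, so the compounds shown cannot say which of the two accounts for the step, or whether the answer lies in the pair of them. A cyclopentylamino group, which keeps the amine hydrogen on a saturated ring, or a benzylamino group, which sets the aromatic ring one carbon further out, would help to pull these apart, while a piperidin-1-yl or morpholin-4-yl group would test whether the result extends to other saturated rings.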